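The source may report more compounds than this note shows. Statements on the series, on what has been measured and on what is new or still open speak of the compounds shown alone.

In a functional assay on HT-29 cells (Homo sapiens) for cytotoxicity, read by MTT assay, with a stated time of 72 h (on this read-out lower numbers stand for stronger inhibition and higher numbers for weaker inhibition), compound 1 `COc1cc2c(Oc3ccc(NC(=O)c4cc(-c5ccccc5)nc5ccccc45)cc3F)ccnc2cc1OCCCN1CCCCC1` gives 530 nM. Compound 2 `COc1ccc(-c2cc(C(=O)Nc3ccc(Oc4ccnc5cc(OCCCN6CCCCC6)c(OC)cc45)c(F)c3)c3ccccc3n2)cc1` gives 690 nM in this assay, and compound 3 `COc1cc2c(Oc3ccc(NC(=O)c4cc(-c5ccc(Cl)c(Cl)c5)nc5ccccc45)cc3F)ccnc2cc1OCCCN1CCCCC1` gives 1210 nM in this assay. Compound 2 thus sits second highest of the three numbers: the step of a 1.3-fold higher number from compound 1 to compound 2 (0.11 log units; within the scatter) is within the scatter, as is the step of a 1.8-fold higher number from compound 2 to compound 3 (0.24 log units; within the scatter), while the step of a 2.3-fold higher number from compound 1 to compound 3 (0.36 log units; beyond the scatter) is the only one that reaches beyond it.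

Compound 4 `COc1ccc(-c2cc(C(=O)Nc3ccc(Oc4ccnc5cc(OCCCN6CCC(C)CC6)c(OC)cc45)c(F)c3)c3ccccc3n2)cc1` differs from compound 2 by methyl in place of hydrogen on a saturated ring carbon. Within the data shown here, the three measured steps all concern the aryl group attached to the shared core; none of them touches the piperidine ring, so no measured step bears on this change. The added methyl is a single carbon without donors, acceptors or charge, and on that basis compound 4 is expected to show a step of a 1.0-fold higher number from compound 2 to compound 4 (0.01 log units; within the scatter) in this assay, with no direction resolved beyond the scatter. Compound 4 is therefore estimated at 700 nM in this assay, with a range from 350 nM to 1400 nM.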

Compound 4, half-maximal inhibitory concentration: 1110 nM
Beside the measured number, compound 4's estimate is 1.6-fold (0.20 log units) below it, within the range that was stated.
By their numbers in this assay, from the lowest: compounds 1, 2, 4 and 3 (each within the scatter of the next, the first and the last beyond it).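

In this assay, among these compounds, moving from piperidin-1-yl to 4-methylpiperidin-1-yl gives a 1.6-fold higher number from compound 2 to compound 4 (0.21 log units; within the scatter), the first measured step at the saturated ring rather than at the aryl group on the shared core. With 4-methoxyphenyl held constant, a methyl on a saturated ring carbon, three ring bonds from the ring nitrogen, therefore produces no change beyond the scatter in this read-out. Nothing available accounts for the size of this step or explains the result.

The compounds shown leave open how a hydroxyl group or a longer chain such as propyl would read at this ring carbon, or how a morpholine would read in place of the piperidine. They also leave open whether the same methyl would give a similar step with the phenyl of compound 1 or the 3,4-dichlorophenyl of compound 3.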